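Hydroxy in place of hydrogen across two cores

The compounds below may be only part of what the source reports. "The series", "measured", "known", "first", "only" and "open" are said of these compounds alone.

Compound 1 `CCn1ccc2cc(Cc3cc(OC)c(OC)c(OC)c3)ccc21` and compound 2 `COc1ccc(Cc2ccc3ccccc3c2)c(OC)c1OC` differ in their cores; the difference between the two cores is not broken down here. In a functional assay on HeLa cells (Homo sapiens) for cytotoxicity, read by XTT assay, with a stated time of 72 h (a lower number here means a stronger inhibitor, a higher number a weaker inhibitor), compound 1 gives 17 nM, the lowest of the two numbers, and compound 2 gives 200 nM. Compound 3 `COc1ccc(C(O)c2ccc3ccccc3c2)c(OC)c1OC` carries hydroxy in place of hydrogen on a saturated chain carbon bound to two aromatic carbons on the core of compound 2. For compound 3 this assay reports only a limit, > 10000 nM. The step of an at least 50-fold higher number from compound 2 to compound 3 (1.69 log units; beyond the scatter) rests on (the limit of > 10000 nM in this assay, at which 1 of the 3 values shown sits). Compound 4 `CCn1ccc2cc(C(O)c3cc(OC)c(OC)c(OC)c3)ccc21` bears the same change on the core of compound 1, namely (hydroxy in place of hydrogen on a saturated chain carbon bound to two aromatic carbons). Because the same change produced an at least 50-fold higher number from compound 2 to compound 3 (1.69 log units; beyond the scatter), compound 4 is expected to give about 2000 nM. The step of a 120-fold higher number from compound 1 to compound 4 (2.07 log units; beyond the scatter) is estimated to be large, in line with the one already seen. There is a real chance that this assay reports only a limit for compound 4.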

Compound 4, half-maximal inhibitory concentration: < 1000 nM
Compound 4: a limit, no number (the forecaster's own chance of this, stated with the estimate: 30%); at least 2.0-fold (0.30 log units) between middle value and limit.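

In this assay, going by these compounds alone, compound 4 is reported only as a limit, < 1000 nM, and no step from compound 1 to compound 4 can be read from it. Still open, going by these compounds, is whether hydroxy in place of hydrogen shifts the number as far on the core of compound 1 as on the core of compound 2.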